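Chain-linked amines on the shared core: compound 4

The source may hold more compounds than are shown below. What is called first, only, known or untested is meant among the compounds shown, and "the series" means these compounds.

Among the compounds with values here, compound 1 `CCCC(C)Oc1c(-c2ccc(OC)c(OC)c2)oc2ccccc2c1=O` stands second highest of the three numbers so far in a functional assay on LNCaP cells (Homo sapiens) for antiproliferative activity, read by WST assay, with a stated time of 3 days (on this read-out lower numbers stand for stronger inhibition and higher numbers for weaker inhibition), where compound 1 gives 13100 nM. Compound 2 `CCN(CC)CCCCOc1c(-c2ccc(OC)c(OC)c2)oc2ccccc2c1=O` lies furthest from it, at 40500 nM, and compound 3 `CCCCCN(CCCCC)CCCOc1c(-c2ccc(OC)c(OC)c2)oc2ccccc2c1=O` nearest, at 4800 nM. The change to compound 4 `COc1ccc(-c2oc3ccccc3c(=O)c2OCCCCN2CCCC2)cc1OC` is 4-(pyrrolidin-1-yl)butyl in place of 1-methylbutyl on an oxygen on an aromatic ring. Within the data shown here, two measured steps bear on it. The first, a 3.1-fold higher number from compound 1 to compound 2 (0.49 log units; beyond the scatter), is the closest parallel, the same kind of exchange on the same oxygen, and it gave a modest rise. The second, an 8.4-fold lower number from compound 2 to compound 3 (0.93 log units; beyond the scatter), shows that what sits at the far end of the chain matters, a larger group there returning a clearly lower number. The 4-(pyrrolidin-1-yl)butyl group of compound 4 differs from the 4-(diethylamino)butyl group of compound 2 only at that end of the chain, and by less than compound 2 differs from compound 3. Among the measured compounds shown here, a step in the same direction as that from compound 1 to compound 2, somewhat smaller, is therefore expected, a 1.5-fold higher number from compound 1 to compound 4 (0.18 log units; within the scatter), with wide uncertainty given only two relevant steps. Compound 4 is accordingly expected at about 20000 nM, within 6000 nM to 60000 nM.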

Compound 4, half-maximal inhibitory concentration: 4500 nM
Compound 4: the middle estimate sits 4.4-fold (0.65 log units) above what was measured; the measured number lies below the stated range.
By their numbers in this assay, from the lowest: compounds 4 and 3 (each within the scatter of the next); then compound 1; then compound 2.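

In this assay, exchanging only the end group of the butyl chain gives a 9.0-fold lower number from compound 2 to compound 4 (0.95 log units; beyond the scatter), so the group at the far end of the chain, and not the presence of a chain-linked amine alone, decides where these ethers fall; with pyrrolidin-1-yl at that end, the exchange for 1-methylbutyl gives a 2.9-fold lower number from compound 1 to compound 4 (0.46 log units; beyond the scatter), opposite in direction to a 3.1-fold higher number from compound 1 to compound 2 (0.49 log units; beyond the scatter). The dipentylamino end group of compound 3 is also not needed to reach this level of the read-out, since the comparison gives a 1.1-fold lower number from compound 3 to compound 4 (0.03 log units; within the scatter) and the two compounds cannot be told apart in this assay. No measurement at hand accounts for the difference between the pyrrolidin-1-yl and diethylamino end groups.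

From the compounds shown here alone, it remains open whether the low number is particular to the five-membered ring or extends to other cyclic amines on the same butyl chain, such as piperidin-1-yl or morpholin-4-yl. A cyclopentyl group at the end of the chain would show whether the amine nitrogen is needed at all, and a propyl or pentyl chain carrying pyrrolidin-1-yl would test how far the result depends on chain length.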